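The compounds below may be only part of what the source reports. "The series", "measured", "known", "first", "only" and "open" are said of these compounds alone.

Measured so far in an ADME assay on Vero cells (Chlorocebus sabaeus) for cytotoxicity, read by WST assay; a higher number here means that more compound is tolerated, a lower number that less compound is tolerated:
- compound 1 `O=c1[nH]c(Nc2cccc(C(F)(F)F)c2)nc2cc(Cl)ccc12`: a limit, > 25000 nM
- compound 2 `O=c1[nH]c(Nc2cc(F)cc(F)c2)nc2cc(C(F)(F)F)ccc12`: a limit, >= 7600 nM
- compound 3 `O=c1[nH]c(Nc2cc(Cl)cc(Cl)c2)nc2cc(C(F)(F)F)ccc12`: 7100 nM

For the measured compounds named here, compound 3 holds the only actual number in this assay; the two other values are limits, namely the limit of > 25000 nM in this assay, at which 1 of the 3 values shown sits, and (the limit of >= 7600 nM in this assay, at which 1 of the 3 values shown sits). Going by the values given here, the single measured step, an at least 1.0-fold lower number from compound 2 to compound 3 (0.02 log units; that floor lies within the scatter), lies within the scatter and concerns the substituents on the nitrogen-linked phenyl ring, not the fused core.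

Compound 4 `Nc1ccc2c(=O)[nH]c(Nc3cc(Cl)cc(Cl)c3)nc2c1` keeps the 3,5-dichlorophenyl of compound 3 and changes the core: amino in place of trifluoromethyl on an aromatic carbon. Among the compounds with values here, no measured step touches this position. Within the data shown here, compound 1 carries chloro in place of trifluoromethyl on the core, but it also differs in the anilino ring, so no single step connects it to compound 3, and its value is only a limit.

Among the measured compounds shown here, with no comparable step available, the working expectation is that the change from compound 3 to compound 4 in this assay stays within the scatter, with the limit of the assay a real possibility, expressed as a 1.4-fold higher number from compound 3 to compound 4 (0.15 log units; within the scatter). The estimated value for compound 4 in this assay is 10000 nM, with the expected range running from 4000 nM to 25000 nM.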

Compound 4, half-maximal cytotoxic concentration: > 25000 nM
Compound 4 was reported as a limit (the forecaster's own chance of this, stated with the estimate: 40%); middle value at least 2.5-fold (0.39 log units) away from the limit.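

In this assay, the position on the shared core that carries trifluoromethyl in compound 3 now has its first readable step: amino in place of trifluoromethyl on an aromatic carbon gives an at least 3.5-fold higher number from compound 3 to compound 4 (0.54 log units; beyond the scatter). For the compounds shown here, the one earlier step, on the substituents of the nitrogen-linked phenyl ring, stayed within the scatter, whereas this change on the core, with the 3,5-dichlorophenyl held constant, moves the read-out beyond the scatter. Compound 4 stands as a limit, so the step gives only a floor and not its full size: the limit of > 25000 nM in this assay, at which 2 of the 4 values shown sit.

Still open is whether the shift belongs to the amino group itself or to the loss of trifluoromethyl, since the only other group shown at this position is the chloro of compound 1, which also differs in the nitrogen-linked phenyl ring. Plain hydrogen, a methoxy group, an acylated amine or a carboxylic acid at this position would help separate the two, and whether the step carries over to the 3,5-difluorophenyl of compound 2 is equally unsettled.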